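Second Fluorine on the Linker Ring: Cytotoxicity Outlook

This account rests on a few compounds, and the source may have more. Where it says the series, first, only, none or still open, it means among the compounds named here.

Compound 1, `O=[N+]([O-])c1cn2c(n1)OC[C@@H](OCc1ccc(-c3ccc(OC(F)(F)F)cc3)cc1)C2`: > 128000 nM in an ADME assay on Vero cells (Chlorocebus sabaeus) for cytotoxicity, with a stated time of 72 h; a higher number here means a weaker inhibitor, a lower number a stronger inhibitor
Compound 2, `O=[N+]([O-])c1cn2c(n1)OC[C@@H](OCc1ccc(-c3ccc(OC(F)(F)F)cc3)cc1F)C2`: > 128000 nM

Both readings are limits of this assay rather than numbers. For the measured compounds named here, for compound 2 the value is only such a limit, and the same holds for the one other value shown, as the limit of > 128000 nM in this assay, at which 2 of the 2 values shown sit, records. The step that the two limits leave unreadable from compound 1 to compound 2 therefore cannot be sized: two limits cannot be compared. Compound 3, `O=[N+]([O-])c1cn2c(n1)OC[C@@H](OCc1c(F)cc(-c3ccc(OC(F)(F)F)cc3)cc1F)C2`, is not yet measured. It differs from compound 2 by fluoro in place of hydrogen on an aromatic carbon. Going by the values given here, the only measured step bearing on this kind of change is the unreadable one from compound 1 to compound 2, so no direction or size can be drawn from it. Compound 3 is expected to give 200000 nM, within a range of 100000 nM to 600000 nM. The expected step is a step that the limit leaves unreadable from compound 2 to compound 3, most likely again reported only as a limit.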

Compound 3, half-maximal inhibitory concentration: > 128000 nM
Compound 3: only a limit was reported; the forecaster's own chance of this, stated with the estimate: 85%; the middle value does not contradict the limit.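

Compound 3 gives > 128000 nM in this assay, which is a limit and not a number, and no step between compound 2 and compound 3 can be read: the limit of > 128000 nM in this assay, at which 3 of the 3 values shown sit.

Still open, from the compounds shown here alone, is the concentration at which compound 1, compound 2 or compound 3 would harm these cells, and whether adding fluoro changes that concentration at all.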